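Methylthiazole Replaces Methylpiperazine: A Fall Expected

A few compounds are considered here, and "the series" means these few. Any claim that something is new, unique, unknown or untested is made for them only; others in the source may bear on it.

Compound 3 `CN1CCN(c2noc(-c3cc(O)c(O)c([N+](=O)[O-])c3)n2)CC1` stands highest of the three compounds measured; in a functional assay on the whole organism (liver, strain NMRI) for inhibition, with Mus musculus as the target, with a stated time of 3 h, at a dose of 3 mg/kg by the oral route (a lower number here means less inhibition, a higher number more inhibition at the dose given (going by the name of the read-out)), compound 3 gives 56.8%. Compound 1 `O=[N+]([O-])c1cc(-c2nc(-c3ccc(F)cc3)no2)cc(O)c1O` gives 12.7% in this assay, and compound 2 `O=[N+]([O-])c1cc(-c2nc(-c3ccc(Br)cc3)no2)cc(O)c1O` gives 12.7%; the step of no change at the digits printed from compound 1 to compound 2 (within the scatter) shows the two halogens give the same number. The steps of a number 44.1 percentage points higher from compound 1 to compound 3 (beyond the scatter) and a number 44.1 percentage points higher from compound 2 to compound 3 (beyond the scatter) show that the whole large gain arrives with the 4-methylpiperazin-1-yl group. Compound 4 `Cc1nc(-c2noc(-c3cc(O)c(O)c([N+](=O)[O-])c3)n2)cs1` differs from compound 3 by 2-methyl-1,3-thiazol-4-yl in place of 4-methylpiperazin-1-yl on an aromatic carbon. Because a number 44.1 percentage points higher from compound 1 to compound 3 (beyond the scatter) and a number 44.1 percentage points higher from compound 2 to compound 3 (beyond the scatter) attach that gain to the leaving group, and the entering group is again an aromatic ring, a drop back toward compounds 1 and 2 is expected, of size a number 36.8 percentage points lower from compound 3 to compound 4 (beyond the scatter). Compound 4 is therefore estimated to give 20%, between 5% and 40%.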

Compound 4, a percentage reported as inhibition, in the whole organism at one dose (the size of the read-out at that dose, not a potency): 22.9%
The estimate for compound 4 lay 2.9 percentage points below the measured number; the measured number falls inside the stated range.
By their numbers in this assay, from the lowest: compounds 1 and 2 (each within the scatter of the next); then compound 4; then compound 3.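

In this assay the 2-methyl-1,3-thiazol-4-yl group loses most of the gain, with a number 33.9 percentage points lower from compound 3 to compound 4 (beyond the scatter) in a large step, yet it does not return fully to the level of the halogenated phenyl compounds, with a number 10.2 percentage points higher from compound 1 to compound 4 (beyond the scatter) and a number 10.2 percentage points higher from compound 2 to compound 4 (beyond the scatter) as modest steps. The aromatic groups at this place are therefore not interchangeable, although the 4-methylpiperazin-1-yl group remains well above all three. Nothing measured here accounts for this order. The compounds shown leave open whether the gain needs the whole 4-methylpiperazin-1-yl ring or only an amine. Morpholine or an open-chain dimethylamino group at this place would help to separate the two.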